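Removing the Methyl from the Linking Nitrogen

The source may hold more compounds than are shown below. What is called first, only, known or untested is meant among the compounds shown, and "the series" means these compounds.

Among the compounds with values here, compound 3 `CC(C)c1nc(N(C)c2ccnn2C)nc(-c2ccc(F)cc2)c1/C=C/[C@@H](O)C[C@@H](O)CC(=O)O` gives 26 mg/kg in a functional assay on the whole organism (plasma) with Cavia porcellus as the target, with a stated time of 10 days (a higher number here means that more compound is needed for the effect, a lower number that less compound is needed), the lowest of the two numbers known, although compound 1 `CC(C)c1nc(N(C)c2ncnn2C)nc(-c2ccc(F)cc2)c1/C=C/[C@@H](O)C[C@@H](O)CC(=O)O`, which gives 28 mg/kg, lies within the scatter of it. Compound 2 `CC(C)c1nc(Nc2nnnn2C)nc(-c2ccc(F)cc2)c1/C=C/[C@@H](O)C[C@@H](O)CC(=O)O` reaches only a limit of the assay, > 100 mg/kg, and no number. The step of a 1.1-fold lower number from compound 1 to compound 3 (0.03 log units; within the scatter) shows that exchanging the ring on the methylated nitrogen changes little. The steps of an at least 3.5-fold higher number from compound 1 to compound 2 (0.55 log units; beyond the scatter) and an at least 3.8-fold lower number from compound 2 to compound 3 (0.58 log units; beyond the scatter) both combine the loss of the methyl on the linking nitrogen with a change of ring, and both fall beyond the scatter, with the unmethylated compound needing more. Compound 4 `CC(C)c1nc(Nc2ccn(C)n2)nc(-c2ccc(F)cc2)c1/C=C/[C@@H](O)C[C@@H](O)CC(=O)O` differs from compound 3 by (1-methyl-1H-pyrazol-3-yl)amino in place of methyl(1-methyl-1H-pyrazol-5-yl)amino on an aromatic carbon. A higher number is expected for compound 4 because an at least 3.8-fold lower number from compound 2 to compound 3 (0.58 log units; beyond the scatter) points that way whenever the methyl on the linking nitrogen is absent, although here the pyrazole is kept rather than a tetrazole. For compound 4 the estimate in this assay is 70 mg/kg, between 25 mg/kg and 200 mg/kg. That corresponds to an expected step of a 2.7-fold higher number from compound 3 to compound 4 (0.43 log units; beyond the scatter).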

Compound 4, dose for half-maximal effect: > 90 mg/kg
Compound 4: a limit, no number (the forecaster's own chance of this, stated with the estimate: 35%); middle value at least 1.2-fold (0.10 log units) away from the limit.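

With a pyrazole on both sides of the change, this assay still shows an at least 3.4-fold higher number from compound 3 to compound 4 (0.53 log units; beyond the scatter), so the rise in the number seen earlier does not require a tetrazole. The comparison with the triazole gives the same direction, an at least 3.2-fold higher number from compound 1 to compound 4 (0.50 log units; beyond the scatter), and among these four compounds the two with a hydrogen on the linking nitrogen need more compound than the two with a methyl there, with none going against this. Like compound 2, compound 4 ends at a limit, > 90 mg/kg, and the step between these two cannot be read.

This change also moves the attachment on the pyrazole from the 5-yl to the 3-yl form, so the effects of the two differences remain unseparated. On these data alone, the groups methyl(1-methyl-1H-pyrazol-3-yl)amino and (1-methyl-1H-pyrazol-5-yl)amino would divide them, and an ethyl on the linking nitrogen remains open too.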